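Series notes: aryl swap on the shared core, compound 4

A few compounds are considered here, and "the series" means these few. Any claim that something is new, unique, unknown or untested is made for them only; others in the source may bear on it.

Of the compounds shown here, three built on the shared core have been measured in a functional assay on HepG2 cells (Homo sapiens) for cytotoxicity, read by sulforhodamine B assay, with a stated time of 48 h; on this read-out higher numbers stand for weaker inhibition and lower numbers for stronger inhibition. Compound 1 `CCOC(=O)c1c(-c2ccco2)c(C#N)c(=O)n(/N=C(\C)c2ccc(NS(=O)(=O)c3ccc(Cl)cc3)cc2)c1N` gives 10300 nM; compound 2 `CCOC(=O)c1c(-c2ccc(C)cc2)c(C#N)c(=O)n(/N=C(\C)c2ccc(NS(=O)(=O)c3ccc(Cl)cc3)cc2)c1N` gives 8380 nM; compound 3 `CCOC(=O)c1c(/C=C/c2ccccc2)c(C#N)c(=O)n(/N=C(\C)c2ccc(NS(=O)(=O)c3ccc(Cl)cc3)cc2)c1N` gives 10700 nM. Compound 3 sits at the top end of these three numbers, but only nominally, since both gaps to it are within the scatter: a 1.0-fold higher number from compound 1 to compound 3 (0.02 log units; within the scatter) and a 1.3-fold higher number from compound 2 to compound 3 (0.11 log units; within the scatter). The same aromatic carbon was also varied between the other two measured compounds, again without leaving the scatter: a 1.2-fold lower number from compound 1 to compound 2 (0.09 log units; within the scatter).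

Compound 4 `CCOC(=O)c1c(-c2ccccc2OC)c(C#N)c(=O)n(/N=C(\C)c2ccc(NS(=O)(=O)c3ccc(Cl)cc3)cc2)c1N` has not yet been measured. Relative to compound 3 the change is 2-methoxyphenyl in place of 2-phenylethenyl on an aromatic carbon. Every step made so far at this aromatic carbon moved the read-out by less than the scatter, so the entry of 2-methoxyphenyl is expected to give no step beyond the scatter in this assay either: a 1.1-fold lower number from compound 3 to compound 4 (0.03 log units; within the scatter). Compound 4 is therefore estimated at 10000 nM, with a range from 5000 nM to 20000 nM.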

Compound 4, half-maximal inhibitory concentration: 11400 nM
Compound 4: middle estimate off by 1.1-fold (0.06 log units), on the low side, within the range that was stated.
By their numbers in this assay, from the lowest: compounds 2, 1, 3 and 4 (each within the scatter of the next).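

At the aromatic carbon opposite the ring nitrogen, 2-methoxyphenyl adds a hydrogen-bond acceptor and removes the double bond outside aromatic rings carried by 2-phenylethenyl, yet in this assay this exchange does not separate the two compounds (a 1.1-fold higher number from compound 3 to compound 4 (0.03 log units; within the scatter)). The new group also stays within the scatter of the other two groups at this position (a 1.4-fold higher number from compound 2 to compound 4 (0.13 log units; within the scatter); a 1.1-fold higher number from compound 1 to compound 4 (0.04 log units; within the scatter)), so furan-2-yl, 4-methylphenyl, 2-phenylethenyl and 2-methoxyphenyl cannot be told apart here. Nothing available explains this insensitivity to the exchanged groups.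

Still open, on these data alone, is whether a group of another kind at this carbon, such as an amine, a carboxylic acid or a longer alkyl chain, would move the read-out beyond the scatter. Also open, as far as these compounds go, is whether this insensitivity would persist with the cyano or ethoxycarbonyl group changed.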